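Changing the Aryl Group on the Ring Nitrogen

The source may report more compounds than this note shows. Statements on the series, on what has been measured and on what is new or still open speak of the compounds shown alone.

Measured compounds:
Compound 1 `C/C(=C\CC/C(C)=C/CC[C@@H]1[C@@]2(C)CCC(=O)C(C)(C)[C@H]2CC[C@@]1(C)O)CC/C=C(\C)C(=O)OCc1cn(-c2ccc(C(F)(F)F)cc2)nn1`, in a functional assay on A549 cells (Homo sapiens) for antiproliferative activity, read by MTT assay, with a stated time of 48 h (on this read-out lower numbers stand for stronger inhibition and higher numbers for weaker inhibition), compound 1 gives > 150000 nM, a limit of the assay.
Compound 2 `C/C(=C\CC/C(C)=C/CC[C@@H]1[C@@]2(C)CCC(=O)C(C)(C)[C@H]2CC[C@@]1(C)O)CC/C=C(\C)C(=O)OCc1cn(-c2ccccc2Cl)nn1`, compound 2 gives > 150000 nM, also a limit.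
Compound 3 `C/C(=C\CC/C(C)=C/CC[C@@H]1[C@@]2(C)CCC(=O)C(C)(C)[C@H]2CC[C@@]1(C)O)CC/C=C(\C)C(=O)OCc1cn(-c2cccc(C(F)(F)F)c2)nn1`, compound 3 gives > 150000 nM, again a limit.

Compound 1 thus stands only at a limit, like every other measured value here: the limit of > 150000 nM in this assay, at which 3 of the 3 values shown sit. The two steps from compound 1, a step that the two limits leave unreadable from compound 1 to compound 2 and a step that the two limits leave unreadable from compound 1 to compound 3, cannot be read, nor can a step that the two limits leave unreadable from compound 2 to compound 3. Compound 4 `C/C(=C\CC/C(C)=C/CC[C@@H]1[C@@]2(C)CCC(=O)C(C)(C)[C@H]2CC[C@@]1(C)O)CC/C=C(\C)C(=O)OCc1cn(-c2cccc(O)c2)nn1` differs from compound 1 by 3-hydroxyphenyl in place of 4-(trifluoromethyl)phenyl on an aromatic nitrogen. With no readable measured step, no direction can be expected for this change, and the most likely outcome is another limit. Compound 4 is therefore estimated at 150000 nM, with a range from 50000 nM to 300000 nM. This estimate corresponds to an expected step of a number no higher from compound 1 to compound 4 (the limit leaves the size open).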

Compound 4, half-maximal inhibitory concentration: 42800 nM
Compound 4: the middle estimate sits 3.5-fold (0.54 log units) above what was measured; the whole stated range lies above it.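

Going by these compounds alone, on the aromatic nitrogen, the choice of aryl group can bring a result off the limit in this assay, something the earlier compounds could not show: the limit of > 150000 nM in this assay, at which 3 of the 4 values shown sit. The 3-hydroxyphenyl group gives an at least 3.5-fold lower number from compound 1 to compound 4 (0.54 log units; beyond the scatter) and an at least 3.5-fold lower number from compound 2 to compound 4 (0.54 log units; beyond the scatter). Hydroxy in place of trifluoromethyl on an aromatic carbon, as the only change, gives an at least 3.5-fold lower number from compound 3 to compound 4 (0.54 log units; beyond the scatter).

Going by these compounds, whether an amine or a carboxylic acid in place of the hydroxy would give a lower number stays open. On these data alone, the steps among compounds 1, 2 and 3 cannot be read, and the full size of the steps to compound 4 also stays open.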